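Pyrimidinyl amide replaces ethylphenyl in a pyridinylpiperazine series

The compounds below may be only part of what the source reports. "The series", "measured", "known", "first", "only" and "open" are said of these compounds alone.

Compound 1 `CCc1cccc(NC(=O)CN2CCN(c3ccccn3)CC2)c1` sits second highest among the three numbers recorded in a functional assay on cells for antagonist activity at D(4) dopamine receptor (Homo sapiens), read by TR-FRET and cAMP accumulation, with a stated time of 30 min (on this read-out lower numbers stand for stronger inhibition and higher numbers for weaker inhibition), where compound 1 gives 1310 nM. Among the measured compounds shown here, its nearest neighbour is compound 3 `CCc1cccc(NC(=O)CN2CCN(c3ccc(Cl)cn3)CC2)c1`, which in this assay gives 7060 nM; the only single-point step in the set runs a 5.4-fold higher number from compound 1 to compound 3 (0.73 log units; beyond the scatter). Far removed stands compound 2 `Cc1cccc(NC(=O)CN2CCC(c3ccccc3)CC2)c1`, which in this assay gives 2 nM, but compound 2 differs from compound 1 in more than one place, so its value shows only that much lower numbers are reachable in this scaffold.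

Compound 4 `O=C(CN1CCN(c2ccccn2)CC1)Nc1cncnc1` is compound 1 with pyrimidin-5-yl in place of 3-ethylphenyl on an amide-type nitrogen. For the measured compounds named here, no measured step touches this part of the molecule; the one step recorded concerns the pyridine end, not the amide-bound aryl group. Going by the values given here, with no direct precedent, the expectation rests on the observation that both measured changes to compound 1 left the number high, and compound 4 is expected to show a step of a 3.4-fold higher number from compound 1 to compound 4 (0.54 log units; beyond the scatter) toward a weaker inhibition. Compound 4 is therefore estimated at 4500 nM, within a range from 1000 nM to 20000 nM.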

Compound 4, half-maximal inhibitory concentration: > 100000 nM
Compound 4 gave a limit, no number; the forecaster's own chance of this, stated with the estimate: 30%; middle value at least 22-fold (1.34 log units) away from the limit.
By their numbers in this assay, from the lowest: compound 2; then compound 1; then compound 3. At a limit, above all of these: compound 4.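

Among the compounds shown here, this is the first measured change at the aryl group on the amide-type nitrogen, and pyrimidin-5-yl in place of 3-ethylphenyl gives an at least 76-fold higher number from compound 1 to compound 4 (1.88 log units; beyond the scatter). That step is larger than the one seen at the pyridine end, a 5.4-fold higher number from compound 1 to compound 3 (0.73 log units; beyond the scatter), so within this pair of changes the amide-bound aryl group is the more sensitive place. For compound 4, the result in this assay is a limit and not a number: the limit of > 100000 nM in this assay, at which 1 of the 4 values shown sits.

The compounds shown leave open whether the step follows the loss of the ethyl group or the entry of the two ring nitrogens, as this single change carries both at once. From the compounds shown here alone, an unsubstituted phenyl or a 3-ethylpyridinyl group on the same nitrogen would separate the two, and how far the number then moves remains unknown.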